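This account rests on a few compounds, and the source may have more. Where it says the series, first, only, none or still open, it means among the compounds named here.

Compounds measured in a functional assay on HeLa cells (Homo sapiens) (a higher number here means a weaker inhibitor, a lower number a stronger inhibitor), so far:
compound 1, `CCCCc1ccc(C(=O)CC(SCC(=O)O)C(=O)O)cc1`: 1910 nM
compound 2, `O=C(O)CSC(CC(=O)c1ccc(F)cc1)C(=O)O`: 20700 nM

Compound 2 stands highest of the two numbers; its nearest neighbour is compound 1, and the step of an 11-fold higher number from compound 1 to compound 2 (1.03 log units; beyond the scatter) separates them. Compound 3, `O=C(O)CSC(CC(=O)c1ccc(Br)cc1)C(=O)O`, is not yet measured. It differs from compound 2 by bromo in place of fluoro on an aromatic carbon. Among the compounds with values here, only one measured step bears on this place on the ring, and it was large. Within the data shown here, no measured step exchanges one halogen for another, so the direction of this change is uncertain. Compound 3 is expected at 7000 nM (range 2000 nM to 25000 nM), an estimated step of a 3.0-fold lower number from compound 2 to compound 3 (0.47 log units; beyond the scatter).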

Compound 3, half-maximal inhibitory concentration: 9510 nM
For compound 3 the middle estimate is 1.4-fold (0.13 log units) below the measured one; measured number inside the range.
By their numbers in this assay, from the lowest: compound 1; then compound 3; then compound 2.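

In this assay the choice of halogen at this place on the ring matters: a 2.2-fold lower number from compound 2 to compound 3 (0.34 log units; beyond the scatter) is the only halogen exchange shown, and it lies beyond the scatter. Bromo does not match butyl, with a 5.0-fold higher number from compound 1 to compound 3 (0.70 log units; beyond the scatter) as the remaining gap, so the three groups rank butyl, then bromo, then fluoro from strongest to weakest. No evidence on hand accounts for this order.

On these data alone, whether chloro would fall between fluoro and bromo, and whether a chain longer than butyl would lower the number further, remains open. Also open, as far as these compounds go, is how an amide in place of either carboxylic acid would read.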